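Amide-to-sulfonamide switch on the anilide series

This account rests on a few compounds, and the source may have more. Where it says the series, first, only, none or still open, it means among the compounds named here.

Three measured compounds share one core and differ only in the group on the anilide nitrogen. In a functional assay on HCT-116 cells (Homo sapiens) for antiproliferative activity, read by MTT assay, with a stated time of 48 h (on this read-out higher numbers stand for weaker inhibition and lower numbers for stronger inhibition), compound 1 `O=C(Nc1cccc(/C=C/C(=O)c2nc3ccccc3[nH]2)c1)c1cccc(Br)c1` gives 1560 nM, compound 2 `Cc1cccc(C(=O)Nc2cccc(/C=C/C(=O)c3nc4ccccc4[nH]3)c2)c1` gives 1420 nM, and compound 3 `COc1ccc(C(=O)Nc2cccc(/C=C/C(=O)c3nc4ccccc4[nH]3)c2)cc1` gives 4880 nM. Compound 3 stands at the highest number of the three: a 3.1-fold higher number from compound 1 to compound 3 (0.50 log units; beyond the scatter) and a 3.4-fold higher number from compound 2 to compound 3 (0.54 log units; beyond the scatter) both run beyond the scatter, while a 1.1-fold lower number from compound 1 to compound 2 (0.04 log units; within the scatter) stays within it.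

Compound 4 `O=C(/C=C/c1cccc(NS(=O)(=O)c2ccc(Cl)cc2)c1)c1nc2ccccc2[nH]1` is unmeasured. Its change from compound 3 is (4-chlorophenyl)sulfonyl in place of (4-methoxyphenyl)carbonyl on a nitrogen on an aromatic ring. Of the measured steps, only those ending at compound 3 bear on this in part, since both swap the aryl group on the carbonyl carbon: a 3.1-fold higher number from compound 1 to compound 3 (0.50 log units; beyond the scatter) and a 3.4-fold higher number from compound 2 to compound 3 (0.54 log units; beyond the scatter) show that leaving the 4-methoxyphenyl recovers a modest lowering. Within the data shown here, no measured step changes the carbonyl to a sulfonyl, so that part of the change has no precedent in the set.

A modest lowering in this assay is therefore expected, roughly back toward the numbers of compound 1 and compound 2, with wide uncertainty: a 2.2-fold lower number from compound 3 to compound 4 (0.35 log units; beyond the scatter). Compound 4 is estimated at 2200 nM, within 700 nM to 7000 nM.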

Compound 4, half-maximal inhibitory concentration: 1960 nM
Compound 4: the middle estimate sits 1.1-fold (0.05 log units) above what was measured, within the range that was stated.
By their numbers in this assay, from the lowest: compounds 2, 1 and 4 (each within the scatter of the next); then compound 3.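

In this assay, (4-chlorophenyl)sulfonyl on this nitrogen is compatible with low-micromolar numbers: a 2.5-fold lower number from compound 3 to compound 4 (0.40 log units; beyond the scatter) is a modest lowering, and it shows that a carbonyl on the anilide nitrogen is not needed to hold the series at this level. Against the other two amides, a 1.4-fold higher number from compound 2 to compound 4 (0.14 log units; within the scatter) and a 1.3-fold higher number from compound 1 to compound 4 (0.10 log units; within the scatter) both stay within the scatter, so compound 4 cannot be told apart from compound 1 or compound 2 on this read-out, and only compound 3 stands apart from the rest of the set. No accompanying measurement offers an account of these steps.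

The change from compound 3 swaps the sulfonyl for the carbonyl and the 4-chlorophenyl for the 4-methoxyphenyl together, and the compounds shown do not separate the two parts. Still open, as far as these compounds go, are how a (4-methoxyphenyl)sulfonyl group would compare directly with compound 3, and whether an amine or a carboxylic acid on the aryl ring of the sulfonyl group, or a longer chain in place of that ring, would keep these numbers.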